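Notes on a hydrazide series: naphthyl in place of fluorophenyl

A few compounds are considered here, and "the series" means these few. Any claim that something is new, unique, unknown or untested is made for them only; others in the source may bear on it.

Three compounds of the series have a number in a physicochemical assay for lipophilicity; a lower number here means a more polar compound, a higher number a more lipophilic compound. Compound 1 `N=C(N)Nc1cccc(C(=O)NNC(=O)CC(CC(=O)O)c2ccc(F)cc2)c1` gives 1.28 in this assay. Compound 2 `O=C(O)CC(CC(=O)NNC(=O)CCCCNc1ccccn1)c1cc(Cl)cc(Cl)c1` gives 3.19 in this assay. Compound 3 `O=C(O)CC(NC(=O)NNC(=O)CCCCNc1ccccn1)c1ccc(F)cc1` gives 1.8 in this assay, the second highest of the three numbers: compound 1 sits lower and compound 2 sits higher, and both of these gaps lie beyond the usual scatter of this assay. Among the measured compounds shown here, no pair of the measured compounds differs in a single place, so no measured step is available.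

Compound 4 `O=C(O)CC(NC(=O)NNC(=O)CCCCNc1ccccn1)c1cccc2ccccc12` differs from compound 3 in one place: naphthalen-1-yl in place of 4-fluorophenyl on a saturated chain carbon bound to an amide-type nitrogen and a saturated chain carbon. For the measured compounds named here, no measured step covers this exchange. Two aromatic rings of carbon now stand where one carbon ring with a fluorine stood, and on that count a clear rise in this assay is expected. The step of a number 1.10 log units higher from compound 3 to compound 4 (beyond the scatter) is expected to be upward and beyond the scatter. Compound 4 is therefore estimated at 2.9, with a range from 2.3 to 3.5.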

Compound 4, partition coefficient: 2.64
Compound 4: middle estimate off by 0.26 log units, on the high side; the measured number falls inside the stated range.
By their numbers in this assay, from the lowest: compound 1; then compound 3; then compound 4; then compound 2.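

In this assay, among the compounds shown here, naphthalen-1-yl in place of 4-fluorophenyl on a saturated chain carbon bound to an amide-type nitrogen and a saturated chain carbon gives a number 0.84 log units higher from compound 3 to compound 4 (beyond the scatter), the first step that can be read at a single place. It shows that this position is not silent in this assay: the number moves with the exchange of the aromatic group alone, with the counted hydrogen-bond donors, hydrogen-bond acceptors and net charge of the group unchanged. Nothing available explains the size of this step.

On these data alone, a plain phenyl group at this place would separate the contribution of the fluorine from that of the second ring, and where it would stand remains open. As far as these compounds go, whether the same exchange gives a similar step on the core of compound 1 also remains open.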